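This account rests on a few compounds, and the source may have more. Where it says the series, first, only, none or still open, it means among the compounds named here.

Compound 1 `Cc1cccc2c(NCc3ccco3)nc(NC(C)C)nc12` and compound 2 `Cc1cccc2nc(NC(C)C)nc(NCc3ccco3)c12` are built from the same atoms joined differently, and how the two cores differ is not broken down here. In a physicochemical assay for lipophilicity, at pH 7.4 (on this read-out lower numbers stand for lower lipophilicity and higher numbers for higher lipophilicity), compound 1 gives 3.55, and compound 2 gives 3.55, the same number at the digits shown. Compound 3 `COc1cccc2c(NCc3ccco3)nc(NC(C)C)nc12` carries the change methoxy in place of methyl on an aromatic carbon on the core of compound 1. In this assay compound 3 gives 3.4, and the step of a number 0.15 log units lower from compound 1 to compound 3 (within the scatter) lies within the usual scatter of this kind of measurement. Compound 4 `COc1cccc2nc(NC(C)C)nc(NCc3ccco3)c12` carries the same change, (methoxy in place of methyl on an aromatic carbon), on the core of compound 2, with the place around it described in the same words for both pairs. Because the measured step of a number 0.15 log units lower from compound 1 to compound 3 (within the scatter) stays within the scatter, a matching move is expected on the second core. Resting on that one measured pair alone, the step expected in this assay is estimated at a number 0.15 log units lower from compound 2 to compound 4 (within the scatter). Compound 4 is therefore expected to give about 3.4 in this assay, with an estimated range from 3.1 to 3.7.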

Compound 4, distribution coefficient: 3.35
Estimate against measurement, compound 4: 0.05 log units above; the range from low to high includes it.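

In this assay the change of methoxy in place of methyl on an aromatic carbon reads as a number 0.20 log units lower from compound 2 to compound 4 (within the scatter) and, on the other core, as a number 0.15 log units lower from compound 1 to compound 3 (within the scatter), so the two pairs agree in that neither step can be told from the scatter. This shows that the change carried from one core to the other without a step beyond the scatter on either, but it does not show that the change has any real effect on this read-out, and two pairs cannot establish that the same would hold on further cores in the series. Nothing given here bears on why the two steps look as they do.

From the compounds shown here alone, whether an amine, a carboxylic acid or a longer chain such as ethoxy on the same aromatic carbon would give a step beyond the scatter on either core stays open. The compounds shown also speak only to this assay, leaving open how this change behaves on any other read-out.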